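Series notes: ether-linked acetamides with varied side-chain terminus

The source may report more compounds than this note shows. Statements on the series, on what has been measured and on what is new or still open speak of the compounds shown alone.

Measured so far in an assay for inhibition of putative inactive group IIC secretory phospholipase A2 (Homo sapiens); a higher number here means a weaker inhibitor, a lower number a stronger inhibitor:
- compound 1, `CCCCCCCCCCCCCCCCCCOCC(CC[S+]([O-])c1ccc(C)cc1)NC(C)=O`: a limit only, > 200000 nM
- compound 2, `CCCCCCCCCCCCCCCCCCOCC(CCC1CO1)NC(C)=O`: a limit only, > 200000 nM
- compound 3, `CCCCCCCCCCCCCCCCCCOCC(CCC(C)=O)NC(C)=O`: a limit only, > 200000 nM

Compound 3 stands at a limit, as do the two others; all three sit at the limit of > 200000 nM in this assay, at which 3 of the 3 values shown sit, so no number separates them. The steps a step that the two limits leave unreadable from compound 1 to compound 2, a step that the two limits leave unreadable from compound 1 to compound 3 and a step that the two limits leave unreadable from compound 2 to compound 3 are unreadable for the same reason.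

Compound 4, `CCCCCCCCCCCCCCCCCCOCC(CCSc1ccc(C)cc1)NC(C)=O`, differs from compound 3 by (4-methylphenyl)sulfanyl in place of acetyl on a saturated chain carbon, three bonds along the chain from an amide-type nitrogen. Compound 4 is closest to compound 1, whose sulfoxide is replaced by the sulfide. Going by the values given here, none of the measured steps can be read, and the only evidence is that every measured compound sits at the limit, so no step beyond the scatter is expected in the readable direction and compound 4 is expected to remain at a limit as well. The step is estimated at a step that the limit leaves unreadable from compound 3 to compound 4. Compound 4 is expected near 300000 nM, ranging from 100000 nM to 1000000 nM.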

Compound 4, half-maximal inhibitory concentration: > 200000 nM
Compound 4 ended at the assay's limit (the forecaster's own chance of this, stated with the estimate: 85%); the middle value is on the limit's open side.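

No step to compound 4 from compound 1, compound 2 or compound 3 can be read, since all four stand at a limit: the limit of > 200000 nM in this assay, at which 4 of the 4 values shown sit.

The compounds shown leave open whether any side-chain terminus on the shared core gives a measurable value in this assay.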